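Indazole substitution in the acrylic acid series: step to compound 4

The source may hold more compounds than are shown below. What is called first, only, known or untested is meant among the compounds shown, and "the series" means these compounds.

Measured so far in a functional assay on MCF7 cells (Homo sapiens) for cytotoxicity, read by CellTiter-Glo, with a stated time of 5 days; on this read-out higher numbers stand for weaker inhibition and lower numbers for stronger inhibition:
compound 1 `CC/C(=C(/c1ccc(/C=C/C(=O)O)cc1)c1ccc2[nH]ncc2c1)c1ccccc1`: 7.2 nM
compound 2 `CC/C(=C(/c1ccc(/C=C/C(=O)O)cc1)c1cc2cn[nH]c2cc1C)c1ccccc1`: 468 nM
compound 3 `CC/C(=C(/c1ccc(/C=C/C(=O)O)cc1)c1cc(C)c2[nH]ncc2c1)c1ccccc1`: 59 nM

Compound 3 stands second highest of the three numbers in this assay; its nearest neighbour is compound 2, and compound 1 lies furthest from it. The two methyl additions to the shared core behave differently: a 65-fold higher number from compound 1 to compound 2 (1.81 log units; beyond the scatter), whereas an 8.2-fold higher number from compound 1 to compound 3 (0.91 log units; beyond the scatter). Comparing the two methyl isomers directly, a 7.9-fold lower number from compound 2 to compound 3 (0.90 log units; beyond the scatter), so where the substituent sits on the indazole decides the size of the loss.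

Compound 4 `CC/C(=C(/c1ccc(/C=C/C(=O)O)cc1)c1ccc2[nH]ncc2c1Cl)c1ccccc1` carries a different substituent at a different place: 4-chloro-1H-indazol-5-yl in place of 7-methyl-1H-indazol-5-yl on a double-bonded chain carbon bound to an aromatic carbon and a double-bonded chain carbon. Within the data shown here, no measured pair covers a halogen on this ring, and no measured pair covers this position, so the steps from compound 1 show only that any substituent on the indazole so far has raised the number, by a modest to large amount. On that basis compound 4 is expected to give a higher number than compound 3, with wide uncertainty; the estimated step is a 3.4-fold higher number from compound 3 to compound 4 (0.53 log units; beyond the scatter). The estimate for compound 4 in this assay is 200 nM, with a range from 30 nM to 1500 nM.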

Compound 4, half-maximal inhibitory concentration: 1.6 nM
Beside the measured number, compound 4's estimate is 130-fold (2.10 log units) above it, and the stated range ends above it.
By their numbers in this assay, from the lowest: compound 4; then compound 1; then compound 3; then compound 2.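

In this assay, among these compounds, the added chloro gives a 4.5-fold lower number from compound 1 to compound 4 (0.65 log units; beyond the scatter), making compound 4 the first compound here with a substituent on the indazole to fall below compound 1, whereas both methyl steps, a 65-fold higher number from compound 1 to compound 2 (1.81 log units; beyond the scatter) and an 8.2-fold higher number from compound 1 to compound 3 (0.91 log units; beyond the scatter), go upward. Against the methyl isomers, 4-chloro-1H-indazol-5-yl in place of 7-methyl-1H-indazol-5-yl gives a 37-fold lower number from compound 3 to compound 4 (1.57 log units; beyond the scatter), and in place of 6-methyl-1H-indazol-5-yl it gives a 290-fold lower number from compound 2 to compound 4 (2.47 log units; beyond the scatter), so a substituent on this group can lower the number as well as raise it, and the spread among the substituted compounds is wide. No accompanying measurement bears on what lies behind these steps.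

Compound 4 differs from compound 2 and compound 3 in both the substituent and its place, so these compounds leave open whether the chloro itself or the carbon carrying it accounts for the drop, a question that methyl on the carbon carrying chloro in compound 4, or chloro on the carbons carrying methyl in compound 2 and compound 3, would address. From the compounds shown here alone, it also remains open how fluoro, bromo, methoxy or nitrile on that same carbon would compare with chloro.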